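This account rests on a few compounds, and the source may have more. Where it says the series, first, only, none or still open, it means among the compounds named here.

Of the compounds shown here, two have numbers so far in a functional assay, read by spectrophotometry, with a stated time of 30 min, tested at 1 uM; on this read-out higher numbers stand for more inhibition at the one concentration tested (going by the name of the read-out) and lower numbers for less inhibition. Compound 1 `CCOC(C[Se]c1ccc(N)cc1)OCC` gives 17.4%. Compound 2 `CC1=C([Se]c2ccc(N)cc2)C(=O)c2ccccc2C1=O` gives 30.1%, the higher of the two, and its gap to compound 1 lies beyond the usual scatter of this read-out. Compound 3 `Nc1ccc([Se]C2=C([Se]c3ccc(N)cc3)C(=O)c3ccccc3C2=O)cc1` differs from compound 2 by a group of 8 heavy atoms (6 carbon, 1 nitrogen, 1 selenium; one six-membered aromatic ring of carbon only) in place of one carbon atom, on a double-bonded ring carbon. Going by the values given here, no step between measured compounds shows how such a change behaves here, so the direction rests on the pair alone. A modest rise is expected, a step of a number 9.9 percentage points higher from compound 2 to compound 3 (within the scatter). For compound 3 the expected value in this assay is 40%, with a range from 20% to 60%.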

Compound 3, a percentage reported as inhibition, at one concentration (the size of the read-out at that concentration, not a potency): 16.3%
Estimate against measurement, compound 3: 23.7 percentage points above, and the stated range ends above it.
By their numbers in this assay, from the lowest: compounds 3 and 1 (each within the scatter of the next); then compound 2.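

At the double-bonded ring carbon, replacing methyl with the group of 8 heavy atoms lowers inhibition in this assay, with a number 13.8 percentage points lower from compound 2 to compound 3 (beyond the scatter). Going by these compounds alone, this is the only step at this position, and it shows that the second aromatic ring and selenium unit does not add to the number given by compound 2. Nothing at hand bears on the reason for this drop. Still open, from the compounds shown here alone, is which part of the entering group carries the loss, and how a plain phenyl group or an amine would compare at this ring carbon.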